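This account rests on a few compounds, and the source may have more. Where it says the series, first, only, none or still open, it means among the compounds named here.

Within the data shown here, only three compounds have numbers so far in a functional assay on LoVo cells (Homo sapiens) for cytotoxicity, read by MTT assay, with a stated time of 72 h; on this read-out higher numbers stand for weaker inhibition and lower numbers for stronger inhibition. Compound 1 `c1ccc2[nH]c(-n3cccn3)cc2c1` gives 86000 nM, compound 2 `Cc1ccc2[nH]c(-n3cccn3)c(C3=C(Br)C(=O)NC3=O)c2c1` gives 27000 nM, and compound 3 `COc1ccc2[nH]c3c4cn[nH]c4c4c(c3c2c1)C(=O)NC4=O` gives 42000 nM. Compound 3 holds the second highest of these three numbers. Its gap to compound 2 lies within the usual scatter of repeated measurements, while compound 1, with the highest number, lies beyond that scatter from compound 3.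

Compound 4 `Cc1ccc2[nH]c3c4cn[nH]c4c4c(c3c2c1)C(=O)NC4=O` keeps the core of compound 3 but has methyl in place of methoxy on an aromatic carbon. Among the measured compounds shown here, no pair of measured compounds shows this change alone, so the data offer no direct guide to its size or direction. Compound 2 also carries a methyl group on a different core, and it gives 27000 nM, within the scatter of compound 3 at 42000 nM. A change beyond the scatter is therefore not expected. The expected step of a 1.2-fold lower number from compound 3 to compound 4 (0.08 log units; within the scatter) is small. For compound 4 the estimate is 35000 nM, with an expected range of 13000 nM to 90000 nM.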

Compound 4, half-maximal inhibitory concentration: 5000 nM
For compound 4 the middle estimate is 7.0-fold (0.85 log units) above the measured one; measured number below the stated range.
By their numbers in this assay, from the lowest: compound 4; then compounds 2 and 3 (each within the scatter of the next); then compound 1.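

Among these compounds, this is the first pair here that differs in one place only, and it shows that the group on this six-membered aromatic ring of the shared core matters: in this assay, methyl in place of methoxy gives an 8.4-fold lower number from compound 3 to compound 4 (0.92 log units; beyond the scatter) on an otherwise unchanged structure. The change looks small, since a group of 2 heavy atoms with 1 hydrogen-bond acceptor gives way to one of 1 heavy atom with none, yet the step lies beyond the scatter. No measurement at hand explains the step.

The compounds shown leave open how a plain hydrogen, a chlorine, an ethyl group or an amine at this position would compare with methyl. They also leave open whether the same swap would act similarly on another core, such as that of compound 2.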